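Nitroimidazole styryl series: cytotoxicity in HeLa cells

The source may report more compounds than this note shows. Statements on the series, on what has been measured and on what is new or still open speak of the compounds shown alone.

Measured so far:
Compound 1 `Cc1ccccc1/C=C/c1ncc([N+](=O)[O-])n1C` — 93300 nM
Compound 2 `Cc1cccc(/C=C/c2ncc([N+](=O)[O-])n2C)c1` — 30900 nM
Compound 3 `Cn1c([N+](=O)[O-])cnc1/C=C/c1ccccc1Br` — 72400 nM

All three were read in an ADME assay on HeLa cells (Homo sapiens) for cytotoxicity, read by resazurin assay, with a stated time of 2 days; on this read-out higher numbers stand for weaker inhibition and lower numbers for stronger inhibition. Compound 2 gives the lowest number, and its gap to compound 3 and to compound 1 is each beyond the scatter. The difference between the cores of compound 1 and compound 2 is not broken down here.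

Compound 1 and compound 3 differ in one place:

bromo in place of methyl on an aromatic carbon

That change made the step of a 1.3-fold lower number from compound 1 to compound 3 (0.11 log units; within the scatter).

Compound 4 `Cn1c([N+](=O)[O-])cnc1/C=C/c1cccc(Br)c1` is not yet measured. It differs from compound 2 by the same kind of change:

bromo in place of methyl on an aromatic carbon

The place is not identical: in compound 3 the bromo sits ortho to a large group, in compound 4 it sits meta to a large group.

For compound 4 in this assay a step of similar size is expected, a 1.2-fold lower number from compound 2 to compound 4 (0.09 log units; within the scatter), because the earlier step of a 1.3-fold lower number from compound 1 to compound 3 (0.11 log units; within the scatter) stayed within the scatter. The estimate for compound 4 is 25000 nM, with the range 10000 nM to 60000 nM.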

Compound 4, half-maximal inhibitory concentration: 87100 nM
Beside the measured number, compound 4's estimate is 3.5-fold (0.54 log units) below it, outside the stated range (above it).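

In this assay, bromo in place of methyl on an aromatic carbon does not carry over as a constant step between these two cores, and the two steps differ: the same change on two cores in this assay, a 1.3-fold lower number (0.11 log units; within the scatter) from compound 1 to compound 3 and a 2.8-fold higher number (0.45 log units; beyond the scatter) from compound 2 to compound 4, 3.6-fold (0.56 log units) apart, beyond the scatter of two such steps. With the bromo meta to a large group, the change gives a 2.8-fold higher number from compound 2 to compound 4 (0.45 log units; beyond the scatter), so the step on the other core is no reliable guide to either the size or the direction of this one. These two pairs show that the outcome of the change depends on the pair, but they do not show whether the place on the ring or another feature of the core accounts for the difference, and they give no rule for a further core.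

From the compounds shown here alone, only methyl and bromo appear here as the changing group, so it remains open how an amine, a carboxylic acid or a longer chain at these places would behave on either core. Going by these compounds, whether the same difference between the two steps would hold on any other read-out also remains open.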